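The source may report more compounds than this note shows. Statements on the series, on what has been measured and on what is new or still open speak of the compounds shown alone.

Compound 1 `CNC(=O)c1cc(Oc2ccc(NC(=O)c3nccc(-c4ccccc4)n3)cc2)ccn1` sets the starting point of this account. In a functional assay on A549 cells (Homo sapiens) for cytotoxicity, read by MTT assay, with a stated time of 72 h (on this read-out lower numbers stand for stronger inhibition and higher numbers for weaker inhibition), compound 1 gives 26200 nM. Two other compounds share its core and carry their own changes elsewhere: compound 2 `CNC(=O)c1cc(Oc2ccc(NC(=O)c3cc(-c4ccc(OC)cc4)ncn3)cc2F)ccn1` gives 34500 nM in this assay, and compound 3 `CNC(=O)c1cc(Oc2ccc(NC(=O)c3nccc(-c4ccc(C)cc4)n3)cc2F)ccn1` gives 33200 nM. The number for compound 1 sits close to those of compound 2 and compound 3, within the usual scatter of each, so none of the three can be set apart from the others on these data.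

Compound 4 `CNC(=O)c1cc(Oc2ccc(NC(=O)c3nccc(-c4ccc([N+](=O)[O-])cc4)n3)cc2)ccn1` has not yet been measured in this assay. It differs from compound 1 in a single place (nitro in place of hydrogen on an aromatic carbon). Within the data shown here, no measured pair in this set shows the same change, so the size of its effect cannot be read from a neighbouring step; the record holds no nitro-bearing compound at all.

With nothing to anchor it, the expectation for compound 4 is a step of a 1.1-fold lower number from compound 1 to compound 4 (0.04 log units; within the scatter) that stays within the scatter. Going by these compounds, compound 4 is therefore estimated at 24000 nM in this assay, with a range from 8000 nM to 65000 nM, the wide band reflecting that the change is untested here.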

Compound 4, half-maximal inhibitory concentration: > 100000 nM
Compound 4 was reported as a limit (the forecaster's own chance of this, stated with the estimate: 15%); at least 4.1-fold (0.61 log units) between middle value and limit.
By their numbers in this assay, from the lowest: compounds 1, 3 and 2 (each within the scatter of the next). At a limit, above all of these: compound 4.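

In this assay compound 4 gives > 100000 nM, which is a limit of the assay and not a number. Nitro in place of hydrogen on an aromatic carbon, para to a large group, gives an at least 3.8-fold higher number from compound 1 to compound 4 (0.58 log units; beyond the scatter), the first step in this account that stands clear of the scatter, and it shows that this place on the six-membered aromatic ring of carbon only is not indifferent to what it carries, something the three earlier compounds, which could not be set apart, did not reveal. The step can be read only as a lower bound, and how far compound 4 truly lies from compound 1 stays unknown: the limit of > 100000 nM in this assay, at which 1 of the 4 values shown sits.

Going by these compounds, whether an amine, a carboxylic acid or a nitrile at the same place would give a number like that of compound 1 or a limit like that of compound 4 remains open, so the weakening cannot yet be tied to nitro alone rather than to any replacement of hydrogen here. Also open, on these data alone, is whether the same change would give a similar step in a compound carrying the fluorine of compound 3.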